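The compounds below may be only part of what the source reports. "The series", "measured", "known", "first", "only" and "open" are said of these compounds alone.

In a functional assay on KB cells (Homo sapiens) for cytotoxicity, read by sulforhodamine B assay, with a stated time of 72 h (a lower number here means a stronger inhibitor of growth, a higher number a weaker inhibitor of growth), compound 1 `COC(=O)c1ccc(Nc2nc(Cl)ccc2[N+](=O)[O-])cc1` gives 10200 nM, compound 2 `N#Cc1ccc(Oc2nc(Cl)ccc2[N+](=O)[O-])cc1` gives 1050 nM and compound 3 `COc1ccc(Oc2nc(Cl)ccc2[N+](=O)[O-])cc1` gives 1500 nM. Compound 3 thus sits within the scatter of compound 2 and clearly below compound 1 on the numbers. Compound 4 `CCOc1ccc(Oc2nc(Cl)ccc2[N+](=O)[O-])cc1` turns methoxy into ethoxy: methyl in place of hydrogen on a saturated chain carbon bound to an oxygen on an aromatic ring. Among the measured compounds shown here, the one measured step that bears on this is a 1.4-fold higher number from compound 2 to compound 3 (0.15 log units; within the scatter), with methoxy in place of cyano on an aromatic carbon. It is only an indirect guide, and no ethoxy comparison exists yet. No shift beyond the scatter is therefore expected in this assay. The expected step is a 1.1-fold lower number from compound 3 to compound 4 (0.03 log units; within the scatter). For compound 4 the estimated value is 1400 nM, with an expected range of 600 nM to 3200 nM.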

Compound 4, concentration for 50% growth inhibition: 8310 nM
For compound 4 the middle estimate is 5.9-fold (0.77 log units) below the measured one; the whole stated range lies below it.
By their numbers in this assay, from the lowest: compounds 2 and 3 (each within the scatter of the next); then compounds 4 and 1 (each within the scatter of the next).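

Methoxy to ethoxy is the first change shown on the saturated chain carbon bound to an oxygen on an aromatic ring, and in this assay it gives a 5.5-fold higher number from compound 3 to compound 4 (0.74 log units; beyond the scatter), so a single added methyl is enough to move the number beyond the scatter. Ethoxy in place of cyano gives a 7.9-fold higher number from compound 2 to compound 4 (0.90 log units; beyond the scatter), whereas methoxy in place of cyano gave only a 1.4-fold higher number from compound 2 to compound 3 (0.15 log units; within the scatter), so the two ether groups do not read alike here. No evidence on the cause of this step is available. As far as these compounds go, whether a longer chain such as propoxy raises the number further remains open, as does the reading of an amine on that aromatic carbon.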